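Removing the Phenyl from Compound 2: Expected Outcome

This account rests on a few compounds, and the source may have more. Where it says the series, first, only, none or still open, it means among the compounds named here.

Compound 1 `O=C(CCc1ccc(Cl)cc1)C(=O)N1CCOCC1`: in an assay on HEK-293T cells for inhibition of phospholipase A and acyltransferase 2 (Homo sapiens), with stated times of 30 min and 20 min (a lower number here means a stronger inhibitor, a higher number a weaker inhibitor), compound 1 gives > 10000 nM, a limit of the assay.
Compound 2 `O=C(CCc1ccc(Cl)cc1)C(=O)N1CC[C@@H](c2ccccc2)C1`: in this assay compound 2 gives > 10000 nM, also a limit.

Compound 2 thus stands at the limit of > 10000 nM in this assay, at which 2 of the 2 values shown sit, so only a limit and no number is known for it. Compound 3 `O=C(CCc1ccc(Cl)cc1)C(=O)N1CCCC1` differs from compound 2 by hydrogen in place of phenyl on a saturated ring carbon. Among the compounds with values here, no step between measured compounds is available, so no size can be read off for this change. Compound 3 is expected to remain weak, with an estimated step that the limit leaves unreadable from compound 2 to compound 3. For compound 3 the estimate in this assay is 20000 nM, from 8000 nM to 60000 nM.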

Compound 3, half-maximal inhibitory concentration: > 10000 nM
Compound 3 gave a limit, no number (the forecaster's own chance of this, stated with the estimate: 85%); the middle value does not contradict the limit.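

No step can be read from compound 2 to compound 3 or from compound 1 to compound 3, because each value is only a limit: the limit of > 10000 nM in this assay, at which 3 of the 3 values shown sit.

The compounds shown leave open how strongly any of the three inhibits.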